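A few compounds are considered here, and "the series" means these few. Any claim that something is new, unique, unknown or untested is made for them only; others in the source may bear on it.

Going by the values given here, in a functional assay on UACC-257 cells (Homo sapiens) for inhibition, read by sulforhodamine B assay, with a stated time of 48 h (a lower number here means a stronger inhibitor of growth, a higher number a weaker inhibitor of growth), compound 1 `COc1cc(-c2cc(/C=C/C(=O)c3ccc(N)cc3)[nH]n2)cc(OC)c1OC` gives 1870 nM, and the only other measured compound, compound 2 `COc1ccc(C(=O)/C=C/c2cc(-c3cc(OC)c(OC)c(OC)c3)n[nH]2)cc1`, gives 1750 nM, within the scatter of it. That one measured step, a 1.1-fold lower number from compound 1 to compound 2 (0.03 log units; within the scatter), changed a substituent on the same ring that is now exchanged. Compound 3 `COc1cc(-c2cc(/C=C/C(=O)c3ccc(F)c(F)c3)[nH]n2)cc(OC)c1OC` carries 3,4-difluorophenyl in place of 4-aminophenyl on a carbonyl carbon. Among the compounds with values here, no measured step matches this exchange directly; the single step touching that ring stayed within the scatter, so the step is expected to be a 1.0-fold lower number from compound 1 to compound 3 (0.02 log units; within the scatter), not clearly beyond the scatter in either direction. Compound 3 is therefore estimated at 1800 nM, with a range from 700 nM to 4500 nM.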

Compound 3, concentration for 50% growth inhibition: 1750 nM
For compound 3 the middle estimate is 1.0-fold (0.01 log units) above the measured one; measured number inside the range.
By their numbers in this assay, from the lowest: compounds 2, 3 and 1 (each within the scatter of the next).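

In this assay the exchange of 4-aminophenyl for 3,4-difluorophenyl on the carbonyl carbon gives a 1.1-fold lower number from compound 1 to compound 3 (0.03 log units; within the scatter) and the exchange of 4-methoxyphenyl for it gives no change at the digits printed from compound 2 to compound 3 (within the scatter) so the position now tolerates a ring with two fluorines as well. An entering group with 0 hydrogen-bond donors and 0 hydrogen-bond acceptors thus stays within the scatter of both earlier groups. No supporting data explain this. The compounds shown leave open whether a carboxylic acid on this ring, or a saturated cyclohexyl in its place, would move the number beyond the scatter.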